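The source may hold more compounds than are shown below. What is called first, only, known or untested is meant among the compounds shown, and "the series" means these compounds.

Compound 1, `CC(C)N(Cc1cccc(OCCCCCC(=O)O)c1)C(=O)c1ccc(-c2cccc(OCc3ccccc3)c2)cc1`: in an ADME assay on BJ cells (Homo sapiens) for cytotoxicity, read by CellTiter-Glo and resazurin assay, with a stated time of 72 h (on this read-out lower numbers stand for an effect already at smaller amounts and higher numbers for an effect only at larger amounts of compound), compound 1 reaches only a limit of the assay, > 26000 nM.
Compound 2, `Cc1nnc(-c2cccc(-c3ccc(C(=O)N(Cc4cccc(OCCCCCC(=O)O)c4)C(C)C)cc3)c2)o1`: in this assay compound 2 likewise stops at a limit, > 26000 nM.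
Compound 3, `CCOC(=O)CCCCCOc1cccc(CN(C(=O)c2ccc(-c3cccc(OCc4ccccc4)c3)cc2)C(C)C)c1`: in this assay compound 3 again gives only a limit, > 26000 nM.

Of the compounds shown here, three have been measured so far, and none of them produced a number. Compound 2 differs from compound 1 by 5-methyl-1,3,4-oxadiazol-2-yl in place of benzyloxy on an aromatic carbon. The step in this assay is a step that the two limits leave unreadable from compound 1 to compound 2. Compound 3 differs from compound 1 by ethyl in place of hydrogen on an oxygen next to a carbonyl group, and here too the step, a step that the two limits leave unreadable from compound 1 to compound 3, cannot be sized, because every value shown sits at the limit of > 26000 nM in this assay, at which 3 of the 3 values shown sit.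

Compound 4, `CCOC(=O)CCCCCOc1cccc(CN(C(=O)c2ccc(-c3cccc(-c4nnc(C)o4)c3)cc2)C(C)C)c1`, has not yet been measured. It differs from compound 3 by 5-methyl-1,3,4-oxadiazol-2-yl in place of benzyloxy on an aromatic carbon. This is the same change that separates compound 2 from compound 1, made on a different core: the two cores differ by ethyl in place of hydrogen on an oxygen next to a carbonyl group. Since the change from compound 1 to compound 2 left the read-out at its limit, the step that the limit leaves unreadable from compound 3 to compound 4 is expected to be small as well, because both compound 1 and compound 2 sit at the limit of > 26000 nM in this assay, at which 3 of the 3 values shown sit. Compound 4 is therefore estimated at 30000 nM in this assay, with a range from 15000 nM to 100000 nM, and most probably the assay will again report only a limit.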

Compound 4, half-maximal effective concentration: > 26000 nM
Compound 4 was reported as a limit; the forecaster's own chance of this, stated with the estimate: 85%; the middle value lies beyond the limit too.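

For the compounds shown here, compound 4 also gives only a limit in this assay, and neither the step from compound 3 to compound 4 nor the one from compound 2 to compound 4 can be read, because all the values shown sit at the same limit: the limit of > 26000 nM in this assay, at which 4 of the 4 values shown sit. The compounds shown leave open whether either change, benzyloxy to 5-methyl-1,3,4-oxadiazol-2-yl or hydrogen to ethyl, shifts the read-out at all.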